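The source may report more compounds than this note shows. Statements on the series, on what has been measured and on what is new or still open speak of the compounds shown alone.

In a functional assay (a lower number here means a stronger inhibitor, a higher number a weaker inhibitor), compound 3 `CC(C)=CCOc1cc(O)c2c(c1)OC(c1ccc(F)cc1)CC2=O` gives 6060 nM, which lies within the scatter of compound 1 `CC(C)=CCOc1ccc2c(c1)OC(c1ccc(F)cc1)CC2=O` at 7320 nM and of compound 2 `COc1ccc(C2CC(=O)c3ccc(OCC=C(C)C)cc3O2)cc1` at 10200 nM. Compound 4 `CC(C)=CCOc1cc(O)c2c(c1)OC(c1ccc(Br)cc1)CC2=O` differs from compound 3 by a single exchange: bromo in place of fluoro on an aromatic carbon. This puts bromo in place of fluoro on an aromatic carbon. Among the compounds with values here, no measured step makes this exact exchange. The closest one also replaces fluoro, a 1.4-fold higher number from compound 1 to compound 2 (0.14 log units; within the scatter), while the hydroxy step, a 1.2-fold lower number from compound 1 to compound 3 (0.08 log units; within the scatter), changes another part of the molecule. Both stayed within the scatter, so no shift beyond it is expected in this assay. The expected step, a 1.1-fold lower number from compound 3 to compound 4 (0.04 log units; within the scatter), is correspondingly small. Compound 4 is estimated at 5500 nM, with an expected range of 2500 nM to 12000 nM.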

Compound 4, half-maximal inhibitory concentration: 2770 nM
Estimate against measurement, compound 4: 2.0-fold (0.30 log units) above; low and high end bracket the measured number.
By their numbers in this assay, from the lowest: compound 4; then compounds 3, 1 and 2 (each within the scatter of the next).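

In this assay, within the data shown here, the exchange of 4-fluorophenyl to 4-bromophenyl gives a 2.2-fold lower number from compound 3 to compound 4 (0.34 log units; beyond the scatter), the only step so far beyond the scatter. The earlier change at this position, methoxy in place of fluoro with a 1.4-fold higher number from compound 1 to compound 2 (0.14 log units; within the scatter), stayed within it, so this position is now shown to respond, if modestly, to the group it carries. No measured data here bear on the reason for this step.

Open, as far as these compounds go, is whether chloro or iodo at this position would give a number closer to compound 3 or to compound 4. Also open, from the compounds shown here alone, is whether bromo gives a similar step on the core of compound 1, which lacks the hydroxy.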